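Swapping the Ring at the Aromatic Carbon of Compound 2

The source may hold more compounds than are shown below. What is called first, only, known or untested is meant among the compounds shown, and "the series" means these compounds.

Compound 2 `O=C(Nc1ccnnc1)c1cc(N2CCCCC2)ccc1OCc1ccccc1` carries a piperidin-1-yl group on an aromatic carbon. Among the measured compounds shown here, in an assay on Sf9 cells for inhibition of Leucine-rich repeat serine/threonine-protein kinase 2 (Homo sapiens), read by TR-FRET, with stated times of 30 min and 2 h (on this read-out higher numbers stand for weaker inhibition and lower numbers for stronger inhibition), compound 2 gives 25.1 nM, the lowest of the two numbers measured so far; compound 1 `O=C(Nc1ccnnc1)c1cc(N2C[C@H]3COC[C@H]3C2)ccc1OCc1ccccc1` gives 50.1 nM. For the measured compounds named here, the one measured step at this carbon, a 2.0-fold lower number from compound 1 to compound 2 (0.30 log units; within the scatter), exchanged one saturated ring for another and stayed within the scatter. Compound 3 `CN1CCC(c2ccc(OCc3ccccc3)c(C(=O)Nc3ccnnc3)c2)CC1` differs from compound 2 by 1-methylpiperidin-4-yl in place of piperidin-1-yl on an aromatic carbon. On that basis the step of a 1.3-fold higher number from compound 2 to compound 3 (0.11 log units; within the scatter) is expected to be none beyond the scatter. Compound 3 is therefore estimated at 32 nM, with a range from 10 nM to 100 nM.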

Compound 3, half-maximal inhibitory concentration: 20 nM
Compound 3: the middle estimate sits 1.6-fold (0.20 log units) above what was measured; the measured number falls inside the stated range.
By their numbers in this assay, from the lowest: compounds 3, 2 and 1 (each within the scatter of the next, the first and the last beyond it).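

In this assay, the step with a 1.3-fold lower number from compound 2 to compound 3 (0.10 log units; within the scatter) shows that this aromatic carbon accepts a piperidine ring joined through a ring carbon, bearing a methyl on its nitrogen, as readily as one joined through that nitrogen. Among the compounds shown here, the other step, with a 2.5-fold lower number from compound 1 to compound 3 (0.40 log units; beyond the scatter), is the first at this position to pass beyond the scatter, though only modestly. Nothing measured here accounts for either step. From the compounds shown here alone, whether piperidin-4-yl without the methyl, or cyclohexyl with no ring nitrogen, would give a similar number remains open.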